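The compounds below may be only part of what the source reports. "The series", "measured", "known", "first", "only" and "open" are said of these compounds alone.

In an ADME assay on MT4 cells (Homo sapiens) for cytotoxicity, read by MTT assay, with a stated time of 4 days (a lower number here means that less compound is tolerated, a higher number that more compound is tolerated), the three measured compounds gave the following results.

Compound 1 `Cc1ccc(-c2c(C)c(-c3ccccc3)c(C(OC(C)(C)C)C(=O)O)c(C)c2NS(C)(=O)=O)cc1C`: the assay reported only its limit, > 50000 nM.
Compound 2 `CNC(=O)Nc1c(C)c(C(OC(C)(C)C)C(=O)O)c(-c2ccc(C)c(C)c2)c(C)c1-c1ccc(C)c(C)c1`: 20000 nM.
Compound 3 `Cc1ccc(-c2c(C)c(-c3ccc(C)c(C)c3)c(C(OC(C)(C)C)C(=O)O)c(C)c2NS(C)(=O)=O)cc1C`: 15000 nM.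

Among the two actual numbers in this assay compound 3 stands lowest; its nearest neighbour is compound 2, and the step of a 1.3-fold lower number from compound 2 to compound 3 (0.12 log units; within the scatter) lies within the scatter, so the two cannot be ordered. Within the data shown here, for compound 1 only a limit is known (the limit of > 50000 nM in this assay, at which 1 of the 3 values shown sits), and the step of an at least 3.3-fold lower number from compound 1 to compound 3 (0.52 log units; beyond the scatter) is the one change that went beyond the scatter, but it concerns the aromatic substituent rather than the nitrogen.

Compound 4 `Cc1ccc(-c2c(C)c(-c3ccc(C)c(C)c3)c(C(OC(C)(C)C)C(=O)O)c(C)c2NC(=O)c2ccccc2)cc1C` differs from compound 3 in one place: benzoyl in place of methylsulfonyl on a nitrogen on an aromatic ring. The step that bears on it is the one at the same nitrogen, from compound 2 to compound 3, where methylsulfonyl replaced methylcarbamoyl and the number moved only within the scatter. On that basis no step beyond the scatter is expected in this assay, so the estimated step of no change at the digits printed from compound 3 to compound 4 (within the scatter) is small. For compound 4 the expected value in this assay is therefore 15000 nM, within a range of 6000 nM to 40000 nM.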

Compound 4, half-maximal cytotoxic concentration: 9100 nM
Compound 4: the middle estimate sits 1.6-fold (0.22 log units) above what was measured; measured number inside the range.
By their numbers in this assay, from the lowest: compounds 4, 3 and 2 (each within the scatter of the next, the first and the last beyond it). At a limit, above all of these: compound 1.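

At the nitrogen on the aromatic ring, going from methanesulfonamido to benzamido brings in a six-membered aromatic ring of carbon only, yet this assay shows a 1.6-fold lower number from compound 3 to compound 4 (0.22 log units; within the scatter), so benzoyl and methylsulfonyl cannot be told apart at this position. Among these compounds, the comparison with the methylcarbamoyl compound adds something new: with phenyl in place of methylamino on the carbonyl carbon, the assay gives a 2.2-fold lower number from compound 2 to compound 4 (0.34 log units; beyond the scatter), the first modest step beyond the scatter at this nitrogen, while compound 3 lies within the scatter of both compound 2 and compound 4. Nothing available here accounts for either step.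

The compounds shown leave open whether an amine or a carboxylic acid on the benzoyl ring, or a longer chain in place of the methyl of methylsulfonyl, would move the number further from that of compound 3. They also leave open whether the change from 3,4-dimethylphenyl to phenyl, which separated compound 3 from compound 1, would have a similar effect with benzoyl on the nitrogen.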